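Working notes: aryl amine variation on a shared core

The compounds below may be only part of what the source reports. "The series", "measured", "known", "first", "only" and "open" are said of these compounds alone.

Measured so far in a functional assay, with a stated time of 6 min; a higher number here means a weaker inhibitor, a lower number a stronger inhibitor:
- compound 1 `COc1ccc(NCn2nc(-c3ccc4c(c3)OCCO4)oc2=S)cc1`: 5830 nM
- compound 2 `S=c1oc(-c2ccc3c(c2)OCCO3)nn1CNC1CCCCC1`: 18400 nM
- compound 3 `Fc1cccc(F)c1NCn1nc(-c2ccc3c(c2)OCCO3)oc1=S`: 3320 nM

Compound 3 gives the lowest of the three numbers in this assay. Its nearest neighbour is compound 1, whose number is higher only within the scatter, so the two cannot be ordered; compound 2 sits further off, and that gap is beyond the scatter.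

Compound 4 `S=c1oc(-c2ccc3c(c2)OCCO3)nn1CNc1cc(Cl)ccc1Cl` is not yet measured. It differs from compound 3 in one place: 2,5-dichlorophenyl in place of 2,6-difluorophenyl on an amine nitrogen

Going by the values given here, two measured steps bear on this. The step of a 5.5-fold lower number from compound 2 to compound 3 (0.74 log units; beyond the scatter) shows that replacing cyclohexyl by an aromatic ring on the amine nitrogen moves the number down by a modest, real margin. The step of a 1.8-fold lower number from compound 1 to compound 3 (0.24 log units; within the scatter) shows that exchanging one aromatic ring for another on that nitrogen stays within the scatter. The change to compound 4 is again an exchange of one substituted phenyl for another, so the second comparison is the closer one, and no step beyond the scatter is expected in this assay, with at most a slight lean downward.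

Compound 4 is therefore expected to give about 2800 nM in this assay, within a range of 1000 nM to 8000 nM. That estimate corresponds to a step of a 1.2-fold lower number from compound 3 to compound 4 (0.07 log units; within the scatter), which is expected to remain within the scatter.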

Compound 4, half-maximal inhibitory concentration: 5420 nM
Estimate against measurement, compound 4: 1.9-fold (0.29 log units) below; the measured number falls inside the stated range.
By their numbers in this assay, from the lowest: compounds 3, 4 and 1 (each within the scatter of the next); then compound 2.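

Compound 4 adds a third substituted phenyl on the amine nitrogen, and in this assay the step of a 1.6-fold higher number from compound 3 to compound 4 (0.21 log units; within the scatter) and the step of a 1.1-fold lower number from compound 1 to compound 4 (0.03 log units; within the scatter) both lie within the scatter, so 2,5-dichlorophenyl, 2,6-difluorophenyl and 4-methoxyphenyl cannot be ordered at this position. The gap to the saturated ring also recurs with a second substituted phenyl, as the step of a 3.4-fold lower number from compound 2 to compound 4 (0.53 log units; beyond the scatter) lies beyond the scatter, and among these four compounds cyclohexyl gives the only number set apart from the others, with no compound going against that split. Nothing available bears on why the phenyl groups group together or why cyclohexyl stands apart.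

The step from 2,6-difluorophenyl to 2,5-dichlorophenyl changes both the halogen and its placement, so the compounds shown cannot separate those two changes, and the phenyl rings shown carry only halogen or methoxy groups. As far as these compounds go, it remains open whether a carboxylic acid or a primary amine on the phenyl ring, a pyridine ring in its place, or a longer chain on the amine nitrogen would move the number beyond the scatter.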